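The source may report more compounds than this note shows. Statements on the series, on what has been measured and on what is new or still open speak of the compounds shown alone.

Compound 2 `CCC[C@H](NC(=O)[C@@H]1C[C@@H]2CN1C(=O)[C@H](C(C)(C)C)NC(=O)OCCCCCCc1cccc3c1CN(C3)C(=O)O2)C(=O)C(=O)NC1CCC1` is the reference point of this series in an ADME assay on Huh-7 cells (Homo sapiens) for cytotoxicity; on this read-out lower numbers stand for higher toxicity in this test and higher numbers for lower toxicity in this test. In this assay compound 2 gives only a limit, > 50000 nM, and no number. Compound 1 `CCC[C@H](NC(=O)[C@@H]1C[C@@H]2CN1C(=O)[C@H](C1CCCC1)NC(=O)OCCCCCCc1cccc3c1CN(C3)C(=O)O2)C(=O)C(=O)CC1CC1` carries a cyclopentyl group in place of the tert-butyl group of the shared core and a cyclopropylmethyl ketone in place of the amide end; in this assay compound 1 likewise gives only a limit, > 50000 nM. Compound 3 `CCC[C@H](NC(=O)[C@@H]1C[C@@H]2CN1C(=O)[C@H](C(C)(C)C)NC(=O)OCCCCCCc1cccc3c1CN(C3)C(=O)O2)C(=O)C(=O)NC(C)CC` is the sec-butyl analogue of compound 2; in this assay compound 3 also gives only a limit, > 50000 nM. Going by the values given here, the single one-place step measured, a step that the two limits leave unreadable from compound 2 to compound 3, cannot be sized because the limit of > 50000 nM in this assay, at which 3 of the 3 values shown sit, holds every value shown; all three sit at the same limit, and none can be ordered against another.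

Compound 4 `C=CCNC(=O)C(=O)[C@H](CCC)NC(=O)[C@@H]1C[C@@H]2CN1C(=O)[C@H](C(C)(C)C)NC(=O)OCCCCCCc1cccc3c1CN(C3)C(=O)O2` differs from compound 2 in one place: allyl in place of cyclobutyl on an amide-type nitrogen. Among the compounds with values here, the only measured step touching this amide-type nitrogen is the unreadable one, so no step beyond the scatter is expected in this assay, and the most likely outcome is another limit. Compound 4 is therefore expected to give 50000 nM, with a range from 20000 nM to 150000 nM, meaning an expected step of a number no higher from compound 2 to compound 4 (the limit leaves the size open).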

Compound 4, half-maximal cytotoxic concentration: > 50000 nM
Compound 4 gave a limit, no number; the forecaster's own chance of this, stated with the estimate: 80%; the middle value lies on the limit itself.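

Compound 4 gives only a limit in this assay, > 50000 nM. The steps to compound 4 from compound 2 and from compound 3 cannot be read, and the compounds stay unordered: the limit of > 50000 nM in this assay, at which 4 of the 4 values shown sit.

The compounds shown leave open whether cyclobutyl, sec-butyl and allyl on the amide-type nitrogen differ at all in this assay.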